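Two Halogenated Anilines and a Third One Still Unmeasured

The source may report more compounds than this note shows. Statements on the series, on what has been measured and on what is new or still open speak of the compounds shown alone.

Compound 2 `CN1CCN(CCCOc2cccc3nc(Nc4ccc(F)c(F)c4)ccc23)CC1` gives 9090 nM in a functional assay on cells (Panel CNS (Carcinoma cell lines), Homo sapiens) for inhibition, read by sulforhodamine B assay, with a stated time of 48 h (a higher number here means a weaker inhibitor of growth, a lower number a stronger inhibitor of growth), the higher of the two numbers in hand. Among the compounds with values here, its only neighbour, compound 1 `CN1CCN(CCCOc2cccc3nc(Nc4ccc(Cl)c(C(F)(F)F)c4)ccc23)CC1`, gives 3670 nM, and the single measured step, a 2.5-fold higher number from compound 1 to compound 2 (0.39 log units; beyond the scatter), shows that changing the halogen pattern on the aniline ring moves the result modestly. Compound 3 `CN1CCN(CCCOc2cccc3nc(Nc4cc(Cl)cc(Cl)c4)ccc23)CC1` differs from compound 2 by 3,5-dichlorophenyl in place of 3,4-difluorophenyl on a nitrogen on an aromatic ring. Within the data shown here, with only one step to rest on, the change is expected to be modest and, by comparison with compound 1, to run toward lower numbers, a step of about a 1.8-fold lower number from compound 2 to compound 3 (0.26 log units; within the scatter). Compound 3 is therefore estimated at 5000 nM, within the range 2000 nM to 13000 nM.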

Compound 3, concentration for total growth inhibition: 3260 nM
For compound 3 the middle estimate is 1.5-fold (0.19 log units) above the measured one; measured number inside the range.
By their numbers in this assay, from the lowest: compounds 3 and 1 (each within the scatter of the next); then compound 2.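

In this assay, 3,5-dichlorophenyl in place of 3,4-difluorophenyl gives a 2.8-fold lower number from compound 2 to compound 3 (0.45 log units; beyond the scatter) and so shows that this position responds to a change of halogens while the heavy-atom count of the group stays the same. The other comparison, a 1.1-fold lower number from compound 1 to compound 3 (0.05 log units; within the scatter), shows that two rings with different substituents can read alike here, leaving compound 2 alone at the higher number. No measurement in hand explains either result. The compounds shown leave open how an unsubstituted phenyl, or a phenyl carrying a methoxy group or a nitrile, would read on this nitrogen.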